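This account rests on a few compounds, and the source may have more. Where it says the series, first, only, none or still open, it means among the compounds named here.

Measured compounds:
compound 1 `COc1cc(C)cc(-c2c(-c3ccnc(-c4ccc(C(C)=O)cc4)c3)cnn2CC#N)c1` — 104%
compound 2 `COc1cc(C)cc(-c2nn(CC#N)cc2-c2ccnc(-c3ccc(N(C)C)cc3)c2)c1` — 103%

Of the compounds shown here, two have been tested in a functional assay on NCI-H460 cells (Homo sapiens) for cytotoxicity, read by sulforhodamine B assay, with a stated time of 48 h, tested at 0.001 uM; on this read-out higher numbers stand for a weaker effect at the one concentration tested and lower numbers for a stronger effect. Compound 1 gives 104% in this assay, and compound 2 gives 103%. The two numbers lie within the scatter of each other, so neither compound can be called stronger or weaker than the other on this read-out; compound 1 simply stands level with compound 2. Both show essentially no effect at the one concentration used.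

Compound 3 `COc1cc(C)cc(-c2c(-c3ccnc(-c4ccc(N(C)C)cc4)c3)cnn2CC#N)c1` has not yet been measured. It differs from compound 1 by dimethylamino in place of acetyl on an aromatic carbon. For the measured compounds named here, no step between measured compounds is available for this change. Since compound 2, which carries the dimethylamino group as well, gives 103%, compound 3 is expected to show no step beyond the scatter, a number 1 percentage points lower from compound 1 to compound 3 (within the scatter). The value of compound 3 in this assay is estimated at 103%, within 93% to 113%.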

Compound 3, a percentage reported as activity, at one concentration (the size of the read-out at that concentration, not a potency): 93%
Compound 3: the middle estimate sits 10 percentage points above what was measured, and the stated range covers the measured number.
By their numbers in this assay, from the lowest: compounds 3, 2 and 1 (each within the scatter of the next, the first and the last beyond it).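

In this assay, for the compounds shown here, the exchange of acetyl for dimethylamino on the aromatic carbon para to a large group gives a number 11 percentage points lower from compound 1 to compound 3 (beyond the scatter) and so provides the first readable step at this position, a modest shift towards a stronger effect. The 4-acetylphenyl to 4-(dimethylamino)phenyl change therefore alters the read-out even at this single low concentration, although the evidence is one pair of compounds. Nothing available explains this step.

From the compounds shown here alone, it remains open whether another group at this position, such as a primary amine, a morpholine ring or a carboxylic acid, would move the read-out further in either direction. The compounds shown also leave open whether the same exchange gives a step of similar size on a different core.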